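This account rests on a few compounds, and the source may have more. Where it says the series, first, only, none or still open, it means among the compounds named here.

Measured so far in a functional assay on Col1 cells (Homo sapiens) for cytotoxicity, read by sulforhodamine B assay, with a stated time of 72 h; on this read-out lower numbers stand for an effect already at smaller amounts and higher numbers for an effect only at larger amounts of compound:
compound 1 `CCCC[C@@H](/C=C\[C@@H]1OC(=O)C=C[C@@H]1O)OC(C)=O` gives 1.6 ug/mL;
compound 2 `CC(=O)O[C@H](/C=C\[C@H]1CC=CC(=O)O1)C[C@@H](OC(C)=O)[C@H](C)OC(C)=O` gives 4.7 ug/mL;
compound 3 `CCCC[C@@H](/C=C\[C@@H]1OC(=O)C=C[C@@H]1OC(C)=O)OC(C)=O` gives 1 ug/mL.

Compound 3 has the lowest number of the three, yet compound 1 sits within the usual scatter of it, and only compound 2 stands clearly apart. Compound 4 `CCCC[C@H](O)/C=C\[C@@H]1OC(=O)C=C[C@@H]1OC(C)=O` arises from compound 3 by hydrogen in place of acetyl on an oxygen on a saturated carbon. Going by the values given here, the one measured step with a comparable change is a 1.6-fold lower number from compound 1 to compound 3 (0.20 log units; within the scatter), where an acetyl was added on a different oxygen and the number barely moved. Removing an acetyl here is therefore expected to give no step beyond the scatter in this assay, with perhaps a slight drift upward. Compound 4 is expected to give 1.8 ug/mL, with a likely range of 0.8 ug/mL to 4 ug/mL, a step of a 1.8-fold higher number from compound 3 to compound 4 (0.26 log units; within the scatter).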

Compound 4, concentration for half-maximal effect: 1.1 ug/mL
The estimate for compound 4 lay 1.6-fold (0.21 log units) above the measured number, within the range that was stated.
By their numbers in this assay, from the lowest: compounds 3, 4 and 1 (each within the scatter of the next); then compound 2.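

In this assay the change from acetoxy to hydroxy on an oxygen on a saturated carbon gives a 1.1-fold higher number from compound 3 to compound 4 (0.04 log units; within the scatter) and stays within the scatter. So at this place, the number does not depend on the acetyl. This extends the earlier step, a 1.6-fold lower number from compound 1 to compound 3 (0.20 log units; within the scatter), which concerned a different oxygen, and the data offer no measurement that would explain either result.

Still open, from the compounds shown here alone, is whether an amine or a methyl ether at this place would leave the number within the scatter. Also open, going by these compounds, is whether a longer chain on the shared core would do the same.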